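Small Oxime Ether Step on an Antiproliferative Series

The source may report more compounds than this note shows. Statements on the series, on what has been measured and on what is new or still open speak of the compounds shown alone.

Compound 1 `CCCCO/N=C/c1c(N)ncnc1Oc1ccc2[nH]c(C)cc2c1F` gives 446 nM here.
Compound 2 `Cc1cc2c(F)c(Oc3ncnc(N)c3/C=N/O)ccc2[nH]1` gives 492 nM here.
Compound 3 `CO/N=C/c1c(N)ncnc1Oc1ccc2ncccc2c1` gives 1830 nM here.

All three values come from a functional assay on A-375 cells (Homo sapiens) for antiproliferative activity (on this read-out lower numbers stand for stronger inhibition and higher numbers for weaker inhibition), and, on this read-out, compound 2 lies within the scatter of compound 1, while compound 3 stands beyond the scatter on the higher side of compound 2. The open question concerns compound 4 `CNCCO/N=C/c1c(N)ncnc1Oc1ccc2[nH]c(C)cc2c1F` and its difference from compound 2, which is 2-(methylamino)ethyl in place of hydrogen on an oxygen and reads in words as 2-(methylamino)ethyl in place of hydrogen on an oxygen. Among the measured compounds shown here, one measured step touches that same oxygen: a 1.1-fold higher number from compound 1 to compound 2 (0.04 log units; within the scatter) for hydrogen in place of butyl. Compound 3 differs from compound 2 in more than one place and gives no clean guide. For the measured compounds named here, no measured compound carries a 2-(methylamino)ethyl group, so the range must stay wide. From the step between compound 1 and compound 2, no change beyond the scatter is expected in this assay here. The expected size is a 1.2-fold lower number from compound 2 to compound 4 (0.07 log units; within the scatter) by this estimate. For compound 4 the estimated value is 420 nM with an expected range from 140 nM to 1300 nM in this assay.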

Compound 4, half-maximal inhibitory concentration: 345 nM
For compound 4 the middle estimate is 1.2-fold (0.09 log units) above the measured one, within the range that was stated.
By their numbers in this assay, from the lowest: compounds 4, 1 and 2 (each within the scatter of the next); then compound 3.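

On the oxygen of the oxime, the step with 2-(methylamino)ethyl in place of hydrogen is a 1.4-fold lower number from compound 2 to compound 4 (0.15 log units; within the scatter) in this assay, and the step with methylamino in place of ethyl on the chain is a 1.3-fold lower number from compound 1 to compound 4 (0.11 log units; within the scatter). Earlier, only butyl and hydrogen could be compared at this oxygen; now a chain carrying an amine also gives a number within the scatter of both, so none of the three groups separates from the others on this read-out. Nothing in the data available bears on why these numbers stay together.

Still open, from the compounds shown here alone, is whether a carboxylic acid at the end of the chain, a dimethylamino group or a longer chain would stay within the scatter too. Going by these compounds, it is also open whether any group on this oxygen can move the number beyond the scatter in this assay.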